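The compounds below may be only part of what the source reports. "The series", "measured", "known", "first", "only" and "open" are said of these compounds alone.

Measured compounds:
- compound 1 `O=C(Nc1cc(C(F)(F)F)ccc1N1CCCC1)c1cccnc1`: "not active" (no number reported)
- compound 2 `CCN(CC)c1ccc(C(F)(F)F)cc1NC(=O)c1cccnc1`: "not active" (no number reported)
- compound 3 `O=C(Nc1cc(C(F)(F)F)ccc1Nc1ccc(Br)cc1)c1cccnc1`: 17800 nM

All three were tested in a functional assay on Jurkat cells (Homo sapiens) for cytotoxicity, read by MTT assay, with a stated time of 48 h; on this read-out higher numbers stand for weaker inhibition and lower numbers for stronger inhibition. Compound 1 gives no number there, only the note "not active" (no number reported), and compound 2 stands the same way with "not active" (no number reported). Compound 3 alone returns a figure, 17800 nM, which is weak. Compound 1 thus sits at the inactive end of what has been measured.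

The next compound, compound 4 `O=C(Nc1cc(C(F)(F)F)ccc1N1CCCC1)c1ccccc1`, differs from compound 1 by phenyl in place of pyridin-3-yl on a carbonyl carbon. Going by the values given here, no measured pair shows this change, so its size in this assay is unknown; the expectation is no clear shift beyond the scatter, with compound 4 most likely also weak or unreported. Compound 4 is estimated at 40000 nM, within 10000 nM to 150000 nM.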

Compound 4, half-maximal inhibitory concentration: "not active" (no number reported)
Nothing numeric was reported for compound 4; no gap can be computed for the estimate.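

Compound 1 and compound 4 both come back without a number, so no step can be read between them. No supporting data bear on this result. The compounds shown leave open what size of shift, if any, benzoyl in place of (pyridin-3-yl)carbonyl produces.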